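The compounds below may be only part of what the source reports. "The series", "measured", "known", "first", "only" and "open" are said of these compounds alone.

Compound 1 `CC1(C)CCc2c(ccc(C(=O)/C=C/c3ccc(OCc4cn(-c5ccc(Br)cc5)nn4)cc3)c2O)O1`: "not active" (no number reported)
Compound 2 `CC1(C)CCc2c(ccc(C(=O)/C=C/c3ccc(OCc4cn(Cc5ccc([N+](=O)[O-])cc5)nn4)cc3)c2O)O1`: 17100 nM
Compound 3 `CCCCCn1cc(COc2ccc(/C=C/C(=O)c3ccc4c(c3O)CCC(C)(C)O4)cc2)nn1`: 191000 nM

These results come from a functional assay on MCF7 cells (Homo sapiens) for antiproliferative activity, read by MTT assay; a lower number here means a stronger inhibitor, a higher number a weaker inhibitor. Of the two compounds with a number, compound 3 has the higher one and is therefore the weaker inhibitor, while compound 1 offers no number for comparison.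

Compound 4 `CCCCCCCCn1cc(COc2ccc(/C=C/C(=O)c3ccc4c(c3O)CCC(C)(C)O4)cc2)nn1` differs from compound 3 in one place: propyl in place of hydrogen on a saturated chain carbon, five bonds along the chain from an aromatic nitrogen. The added group is a plain propyl, with no ring.

Within the data shown here, only one measured step bears on this change, and only loosely: an 11-fold higher number from compound 2 to compound 3 (1.05 log units; beyond the scatter). That step is large, but it swaps 4-nitrophenyl for butyl rather than extending a chain. It hints that a bigger group here might lower the number, yet compound 1 goes against that reading, giving "not active" (no number reported). A modest fall in this assay is therefore expected, held with little confidence, and a result without a number remains possible.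

The estimate means a 2.4-fold lower number from compound 3 to compound 4 (0.38 log units; beyond the scatter), an expected step smaller than the measured one. For compound 4 the estimated value is 80000 nM, with an expected range of 15000 nM to 300000 nM.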

Compound 4, half-maximal inhibitory concentration: "not active" (no number reported)
Nothing numeric was reported for compound 4; the estimate stays without a comparison.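

Among these compounds, compound 4 has no number in this assay and so no step from compound 3 to compound 4 can be read. The compounds shown leave open how the longer chain of compound 4 compares in numbers with compound 3. No measurement shown accounts for this result.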